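Methyl on the Core and Cytotoxicity in Cultured Cells

The source may report more compounds than this note shows. Statements on the series, on what has been measured and on what is new or still open speak of the compounds shown alone.

Four pyrimidinone-derived compounds are compared in an ADME assay on MT4 cells (Homo sapiens) for cytotoxicity, read by MTT assay; on this read-out lower numbers stand for higher toxicity in this test and higher numbers for lower toxicity in this test. Compound 1 has the structure `O=C(CSc1nc(Cc2c(Cl)cccc2Cl)cc(=O)[nH]1)c1ccc(F)cc1`. In this assay compound 1 gives > 59000 nM, which is a limit of the assay rather than a number. Compound 2, with the structure `Cc1c(Cc2c(Cl)cccc2Cl)nc(SCC(=O)c2ccc(F)cc2)[nH]c1=O`, differs from compound 1 by methyl in place of hydrogen on an aromatic carbon. In this assay compound 2 gives > 57000 nM, again a limit of the assay. Because both values sit at limits, a step that the two limits leave unreadable from compound 1 to compound 2 cannot be read; the relevant evidence is the limit of > 59000 nM in this assay, at which 1 of the 3 values shown sits, and (the limit of > 57000 nM in this assay, at which 1 of the 3 values shown sits).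

Compound 3 has the structure `O=C(CSc1nc(Cc2c(F)cccc2Cl)cc(=O)[nH]1)c1ccccc1`. Its core differs from that of compound 1, but the difference between the two cores is not broken down here. In this assay compound 3 gives > 13000 nM, once more a limit of the assay, as the limit of > 13000 nM in this assay, at which 1 of the 3 values shown sits, records.

Compound 4, not yet measured, has the structure `Cc1c(Cc2c(F)cccc2Cl)nc(SCC(=O)c2ccccc2)[nH]c1=O` and differs from compound 3 by methyl in place of hydrogen on an aromatic carbon. This is the same kind of change as that from compound 1 to compound 2, though the methyl here sits ortho to a 2-chloro-6-fluorobenzyl group rather than ortho to a 2,6-dichlorobenzyl group. Since all three measured compounds reached only limits, the measured step gives no size to carry over. In this assay the expected step is a step that the limit leaves unreadable from compound 3 to compound 4, resting on compound 3 at > 13000 nM and on compound 2 at > 57000 nM. Compound 4 is therefore estimated at 60000 nM in this assay, most likely again reported only as a limit, within 13000 nM to 250000 nM.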

Compound 4, half-maximal cytotoxic concentration: > 12000 nM
Compound 4: a limit, no number (the forecaster's own chance of this, stated with the estimate: 80%); the middle value lies beyond the limit too.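

In this assay compound 4 gives > 12000 nM, which is a limit of the assay and not a number. Compound 3 also stands at a limit, and the step from compound 3 to compound 4 cannot be read. The compounds shown leave open whether methyl in place of hydrogen on the shared core changes cytotoxicity in these cells at all, and by how much.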